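Adding fluoro to compound 3

The source may hold more compounds than are shown below. What is called first, only, known or untested is meant among the compounds shown, and "the series" means these compounds.

Compound 1 `CCc1ccc(OC)c(COc2ccc(Cl)c(C)c2)c1` gives 40000 nM
Compound 2 `COc1ccc(C(N)=O)cc1COc1ccc(Cl)c(C)c1` gives 640 nM
Compound 3 `COc1ccc(C(N)=O)cc1/C=C/c1ccccc1` gives 2400 nM

In a functional assay on HUVEC cells (Homo sapiens) for inhibition, with a stated time of 4 days (a lower number here means a stronger inhibitor, a higher number a weaker inhibitor), compound 3 at 2400 nM holds the middle place, with compound 2 lower at 640 nM and compound 1 higher at 40000 nM among the three. Compound 4 `COc1ccc(C(N)=O)cc1/C=C/c1ccc(F)cc1` differs from compound 3 by fluoro in place of hydrogen on an aromatic carbon and is thus compound 3 with fluoro in place of hydrogen on an aromatic carbon, para to a large group. Among the compounds with values here, the only measured step (a 63-fold lower number from compound 1 to compound 2 (1.80 log units; beyond the scatter)) is large, but it is a different change, carbamoyl in place of ethyl, so no measured step tests fluoro. No shift beyond the scatter is expected, and no direction is favoured. The expected step is small (a 1.1-fold lower number from compound 3 to compound 4 (0.04 log units; within the scatter)). The estimate for compound 4 is 2200 nM (expected range 900 nM to 5000 nM).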

Compound 4, half-maximal inhibitory concentration: 2100 nM
Compound 4: the middle estimate sits 1.0-fold (0.02 log units) above what was measured, and the stated range covers the measured number.
By their numbers in this assay, from the lowest: compound 2; then compounds 4 and 3 (each within the scatter of the next); then compound 1.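

In this assay, fluoro in place of hydrogen on an aromatic carbon, para to a large group, gives a 1.1-fold lower number from compound 3 to compound 4 (0.06 log units; within the scatter), so this single-atom change leaves the number within the scatter. Within the data shown here, it is the first measured step at this place, since the earlier step changed a different part of the molecule. No measurement here offers an explanation for this result.

On these data alone, whether a larger group at this place, such as an amine or a carboxylic acid, would shift the number remains open. Fluoro elsewhere on this ring also remains untested in the compounds shown.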